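A Phenyl Ether Replaces the Amide Side Chain

A few compounds are considered here, and "the series" means these few. Any claim that something is new, unique, unknown or untested is made for them only; others in the source may bear on it.

Of the compounds shown here, three sharing one core have been tested in an assay on isolated protein (strain Sprague-Dawley) for inhibition of Amine oxidase [flavin-containing] A (Rattus norvegicus), read by spectrophotometry, with a stated time of 5 min, tested at 10 uM; a lower number here means less inhibition, a higher number more inhibition at the concentration tested (going by the name of the read-out). Compound 1 `CCOc1cc(=O)oc2cc(OCc3cccc(Cl)c3)ccc12` gives 2%. Compound 2 `CC(=O)COc1cc(=O)oc2cc(OCc3cccc(Cl)c3)ccc12` gives 22%, and compound 3 `O=C(COc1cc(=O)oc2cc(OCc3cccc(Cl)c3)ccc12)N1CCCCC1` gives 9%. Compound 3 thus stands second highest of the three numbers: its nearest neighbour is compound 1, and those two lie within the scatter of each other, while compound 2 sits further off, as seen in a number 13 percentage points lower from compound 2 to compound 3 (beyond the scatter).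

Compound 4 `O=c1cc(Oc2ccccc2)c2ccc(OCc3cccc(Cl)c3)cc2o1` has not yet been measured. It differs from compound 3 in one place: phenyl in place of ((piperidin-1-yl)carbonyl)methyl on an oxygen on an aromatic ring. Seen one bond further out, a ((piperidin-1-yl)carbonyl)methoxy becomes a phenoxy.

The measured steps all alter the chain attached to this same oxygen: a number 20 percentage points higher from compound 1 to compound 2 (beyond the scatter), a number 7 percentage points higher from compound 1 to compound 3 (within the scatter) and a number 13 percentage points lower from compound 2 to compound 3 (beyond the scatter). None of them exchanges that chain for a phenyl, so none bears directly on the step to compound 4. Changes at this oxygen have so far moved the number only modestly, so the step from compound 3 to compound 4 is expected to be small, a number 6 percentage points higher from compound 3 to compound 4 (within the scatter), and could fall either way. Compound 4 is therefore estimated at 15%, with a range from 0% to 40%.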

Compound 4, a percentage reported as inhibition, at one concentration (the size of the read-out at that concentration, not a potency): 0%
The estimate for compound 4 lay 15 percentage points above the measured number; measured number inside the range.
By their numbers in this assay, from the lowest: compounds 4, 1 and 3 (each within the scatter of the next); then compound 2.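

Placing phenyl on this oxygen gives a number 9 percentage points lower from compound 3 to compound 4 (within the scatter) and a number 2 percentage points lower from compound 1 to compound 4 (within the scatter), so in this assay this aromatic ring cannot be told apart from the bulkier ((piperidin-1-yl)carbonyl)methyl of compound 3 or the plain ethyl of compound 1. Only the 2-oxopropyl chain stands apart from phenyl, with a number 22 percentage points lower from compound 2 to compound 4 (beyond the scatter), and compound 2, at 22%, is now separated beyond the scatter from all three other compounds. Nothing available explains why this one chain gives a different reading.

The compounds shown leave open whether a ring reached through one more carbon, as in benzyl, or a ring carrying a substituent, as in chlorophenyl, would read differently from phenyl on this oxygen, and whether a longer ketone chain such as 3-oxobutyl would keep the reading of compound 2. Going by these compounds, each number also comes from a single concentration, so how these compounds would behave at higher concentrations remains unknown.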